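Amide nitrogen substituents on a dihydrofuran carboxamide series

This account rests on a few compounds, and the source may have more. Where it says the series, first, only, none or still open, it means among the compounds named here.

Measured so far:
compound 1 `C=CC1=C(C(=O)NC2CCCCC2)C(c2ccc(OC)cc2)OC1` — in a functional assay on A549 cells (Homo sapiens) for cytotoxicity, read by MTT assay, with a stated time of 24 h (on this read-out higher numbers stand for weaker inhibition and lower numbers for stronger inhibition), compound 1 gives > 100000 nM
compound 2 `C=CC1=C(C(=O)Nc2ccc(C)cc2)C(c2ccc(F)cc2)OC1` — in this assay compound 2 gives > 100000 nM

Both values are limits of the assay rather than numbers. Compound 2 stands at the limit of this assay, and no number is attached to it. The same holds for compound 1, so the two compounds cannot be placed in any order relative to each other; the only shared feature is the limit of > 100000 nM in this assay, at which 2 of the 2 values shown sit.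

Compound 3 `C=CC1=C(C(=O)NCc2ccccc2F)C(c2ccc(F)cc2)OC1` differs from compound 2 at the amide nitrogen: 2-fluorobenzyl in place of 4-methylphenyl on an amide-type nitrogen. Among the measured compounds shown here, no measured step connects any two compounds here, so no direction of change has been observed for a swap of this kind. Given that compound 2 sits at the limit of this assay with > 100000 nM, the expectation for compound 3 is a step that the limit leaves unreadable from compound 2 to compound 3, that is, none beyond the scatter, with compound 3 most likely also reported as a limit. Compound 3 is estimated at 150000 nM, within 50000 nM to 500000 nM.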

Compound 3, half-maximal inhibitory concentration: > 100000 nM
Compound 3 ended at the assay's limit (the forecaster's own chance of this, stated with the estimate: 85%); the middle value lies beyond the limit too.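

In this assay compound 3 gives > 100000 nM as a limit of the assay, not a number. Compound 2 also stands at a limit, so no step can be read between compound 2 and compound 3, and the compounds share only this: the limit of > 100000 nM in this assay, at which 3 of the 3 values shown sit. Left open is whether any amide nitrogen substituent on the shared core gives a readable value in this assay at all.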